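Working notes: from compound 3 to compound 4

A few compounds are considered here, and "the series" means these few. Any claim that something is new, unique, unknown or untested is made for them only; others in the source may bear on it.

Measured in a functional assay on HepG2 cells (Homo sapiens) for antiproliferative activity, read by MTT assay; on this read-out lower numbers stand for stronger inhibition and higher numbers for weaker inhibition:
- compound 1 `CC1(C)CCc2cc(C(=O)/C=C/c3ccc(OCc4cn(-c5ccc(Cl)cc5)nn4)cc3)c(O)cc2O1`: "not active" (no number reported)
- compound 2 `CC1(C)CCc2c(ccc(C(=O)/C=C/c3ccc(OCc4cn(-c5ccc(Br)cc5)nn4)cc3)c2O)O1`: 136000 nM
- compound 3 `COc1ccc(-n2cc(COc3ccc(/C=C/C(=O)c4ccc5c(c4O)CCC(C)(C)O5)cc3)nn2)c([N+](=O)[O-])c1`: 120000 nM

In this assay, compound 3 gives 120000 nM, and it stands level with compound 2 at 136000 nM. The gap between them is a 1.1-fold lower number from compound 2 to compound 3 (0.05 log units; within the scatter), which lies within the scatter. Among the measured compounds shown here, compound 1 offers no number, only "not active" (no number reported), so it provides no step to work from.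

Compound 4 `CC1(C)CCc2c(ccc(C(=O)/C=C/c3ccc(OCc4cn(Cc5ccc([N+](=O)[O-])cc5)nn4)cc3)c2O)O1` is the next to be read. It carries 4-nitrobenzyl in place of 4-methoxy-2-nitrophenyl on an aromatic nitrogen. For the measured compounds named here, the only measured step at this place is a 1.1-fold lower number from compound 2 to compound 3 (0.05 log units; within the scatter), an exchange of one substituted phenyl group for another that left the number within the scatter. Going by the values given here, no measured compound has a benzyl group on this nitrogen, so that step is a weak guide and the range is kept wide.

No shift in either direction beyond the scatter is expected in this assay. The expected step is a 1.1-fold lower number from compound 3 to compound 4 (0.04 log units; within the scatter). For compound 4 the estimate is 110000 nM, with an expected range of 50000 nM to 240000 nM.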

Compound 4, half-maximal inhibitory concentration: 69900 nM
Compound 4: the middle estimate sits 1.6-fold (0.20 log units) above what was measured; the measured number falls inside the stated range.
By their numbers in this assay, from the lowest: compounds 4, 3 and 2 (each within the scatter of the next).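

In this assay, among the compounds shown here, this is the first reading with a benzyl group rather than a directly attached phenyl group on the aromatic nitrogen of the five-membered ring, and the step reads a 1.7-fold lower number from compound 3 to compound 4 (0.23 log units; within the scatter). Against the 4-bromophenyl group, the same position gives a 1.9-fold lower number from compound 2 to compound 4 (0.29 log units; within the scatter), so the read-out does not separate 4-nitrobenzyl from either substituted phenyl group, and this position has so far tolerated a change of ring attachment as well as a change of ring substituents without a step beyond the scatter. No measured evidence bears on this result, and its origin remains unaddressed.

The groups shown at this nitrogen all carry a single aromatic ring, so it remains open whether a morpholine-bearing chain, a carboxylic acid or a longer alkyl chain in that place would give a step beyond the scatter. Also open, going by these compounds, is how unsubstituted benzyl and 4-nitrophenyl would read, a pair that could set the effect of the benzyl link apart from that of the nitro group.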